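The source may report more compounds than this note shows. Statements on the series, on what has been measured and on what is new or still open speak of the compounds shown alone.

Measured compounds:
compound 1 `CCOC(=O)Cn1cc(C(O)c2ccc3ccccc3c2)nn1` — > 100000 nM
compound 2 `OC(c1ccc2ccccc2c1)c1cn(Cc2ccccc2)nn1` — 28800 nM

In a functional assay on B16 cells (Mus musculus) for cytotoxicity, read by MTT assay, with a stated time of 48 h (a lower number here means a stronger inhibitor, a higher number a weaker inhibitor), compound 1 gives > 100000 nM, which is a limit of the assay and not a number. Compound 2 gives 28800 nM in this assay. Between the two, an at least 3.4-fold lower number from compound 1 to compound 2 (0.54 log units; beyond the scatter). Compound 2 thus holds the only number shown in this assay; the other value sits at the limit of > 100000 nM in this assay, at which 1 of the 2 values shown sits.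

Compound 3 `CC1(C)OCC(Cn2cc(C(O)c3ccc4ccccc4c3)nn2)O1` is not yet measured. It differs from compound 2 by 2,2-dimethyl-1,3-dioxolan-4-yl in place of phenyl on a saturated chain carbon bound to an aromatic nitrogen. Going by the values given here, the only measured step touches the same place, swapping ethoxycarbonyl for phenyl, and there phenyl gave the lower number. Compound 3 removes that phenyl again and puts an oxygen-bearing saturated ring in its place, so a move back toward the weaker side is expected, though the new group is not the one that was measured. The step from compound 2 to compound 3 is expected as a 2.4-fold higher number from compound 2 to compound 3 (0.39 log units; beyond the scatter). For compound 3 the estimate in this assay is 70000 nM, with a range from 20000 nM to 250000 nM.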

Compound 3, half-maximal inhibitory concentration: 26900 nM
Beside the measured number, compound 3's estimate is 2.6-fold (0.42 log units) above it; measured number inside the range.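

Replacing phenyl with 2,2-dimethyl-1,3-dioxolan-4-yl on a saturated chain carbon bound to an aromatic nitrogen gives a 1.1-fold lower number from compound 2 to compound 3 (0.03 log units; within the scatter) in this assay, so at this place a six-membered aromatic ring of carbon only is not needed for a number of this size. The separation from the ethoxycarbonyl group now holds for two unlike ring-bearing groups, one aromatic and one non-aromatic with 2 hetero atoms, with an at least 3.7-fold lower number from compound 1 to compound 3 (0.57 log units; beyond the scatter). The value of compound 1 remains a limit and not a number: the limit of > 100000 nM in this assay, at which 1 of the 3 values shown sits.

The compounds shown leave open whether any ring is what matters at this place, as against a longer open chain or a chain ending in an amine. Also open, going by these compounds, is how a carboxylic acid or a free diol would read here.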